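From piperazin-1-yl to 4-isopropylpiperazin-1-yl in compound 1

The compounds below may be only part of what the source reports. "The series", "measured", "known", "first", "only" and "open" are said of these compounds alone.

- Compound 1 `FC(F)(F)Oc1cccc(Nc2nnnc3ccc(N4CCNCC4)nc23)c1`: 8510 nM
- Compound 2 `FC(F)(F)Oc1cccc(Nc2nnnc3ccc(N4CCC(N5CCCCC5)CC4)nc23)c1`: 4900 nM

Both compounds were tested in a functional assay on LNCaP cells (Homo sapiens) for antiproliferative activity, read by MTT assay, with a stated time of 96 h; a higher number here means a weaker inhibitor, a lower number a stronger inhibitor. There, compound 1 gives 8510 nM and compound 2 gives 4900 nM. These two values lie within the usual scatter of repeated measurements, so compound 1 stands level with compound 2 and neither can be ranked ahead.

Compound 3 `CC(C)N1CCN(c2ccc3nnnc(Nc4cccc(OC(F)(F)F)c4)c3n2)CC1`, not yet measured, keeps the core of compound 1 and differs in one place: isopropyl in place of hydrogen on an amine nitrogen in a ring. Put simply, isopropyl stands in place of hydrogen on an amine nitrogen in a ring, turning piperazin-1-yl into 4-isopropylpiperazin-1-yl.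

For the measured compounds named here, no measured pair shows this change on its own, so there is no direct guide to its effect. Going by the values given here, the only anchors are compound 1 at 8510 nM and compound 2 at 4900 nM. Against these, no step beyond the scatter is expected in this assay, with a slight lean towards a lower number. The estimated step is a 1.5-fold lower number from compound 1 to compound 3 (0.19 log units; within the scatter). For compound 3 the estimated value is 5500 nM, with an expected range from 2200 nM to 13000 nM.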

Compound 3, half-maximal inhibitory concentration: 10700 nM
Compound 3: middle estimate off by 1.9-fold (0.29 log units), on the low side, and the stated range covers the measured number.
By their numbers in this assay, from the lowest: compounds 2, 1 and 3 (each within the scatter of the next, the first and the last beyond it).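

In this assay, for the compounds shown here, the step gives the first direct reading of this change: putting isopropyl in place of hydrogen on the amine nitrogen in the ring gives a 1.3-fold higher number from compound 1 to compound 3 (0.10 log units; within the scatter), so compound 1 and compound 3 stand level. At this position, the hydrogen can therefore be exchanged for a group of three carbon atoms with no step beyond the scatter, which means that the free hydrogen on this nitrogen is not needed to keep the number at this level in these cells. No measurement at hand offers an explanation for this result.

Going by these compounds alone, the single step covers only one replacement, so it remains open whether any group on this nitrogen can move the number beyond the scatter, whether a methyl, an acetyl, a longer chain, or a chain ending in a carboxylic acid or an amine. As far as these compounds go, it also remains open whether isopropyl at this position would stay just as silent if the trifluoromethoxy group elsewhere on the molecule were replaced by another group.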